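Fluoro to chloro on the urea aryl ring, two cores

The source may hold more compounds than are shown below. What is called first, only, known or untested is meant among the compounds shown, and "the series" means these compounds.

Compound 1 `CN(C)CCNc1nc(-c2ccc(NC(=O)Nc3ccccc3F)cc2)nc2ccsc12` and compound 2 `CN(C)CCNc1nc(-c2ccc(NC(=O)Nc3ccccc3Cl)cc2)nc2ccsc12` are built on one core; compound 3 `CCN(CC)CCNc1nc(-c2ccc(NC(=O)Nc3ccc(F)cc3)cc2)nc2c(Cl)c(Cl)sc12` and compound 4 `CCN(CC)CCNc1nc(-c2ccc(NC(=O)Nc3ccc(Cl)cc3)cc2)nc2c(Cl)c(Cl)sc12` are built on another, and the difference between the two cores is not broken down here.

In a functional assay on MKN-45 cells (Homo sapiens) for cytotoxicity, read by MTT assay, with a stated time of 72 h (a lower number here means a stronger inhibitor, a higher number a weaker inhibitor), compound 1 gives 530 nM. In this assay compound 2 gives 850 nM. Going by the values given here, the single change between them is chloro in place of fluoro on an aromatic carbon, and it produced a 1.6-fold higher number from compound 1 to compound 2 (0.21 log units; within the scatter). In this assay compound 3 gives 1370 nM. Set against compound 2 this number lies within the scatter; set against compound 1 it lies beyond it.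

Among the compounds with values here, compound 4 is the one compound of the four still to be measured. It differs from compound 3 by chloro in place of fluoro on an aromatic carbon. Within the data shown here, this is the same kind of change as the one from compound 1 to compound 2, but not the same change: there the place is ortho to a large group, here it is para to a large group, and the core beneath it is different. Among the measured compounds shown here, only one measured instance of a fluoro to chloro swap on this ring exists, so the expectation rests on that one step and on the value of compound 3.

From compound 3 to compound 4 in this assay a step of about a 1.4-fold higher number from compound 3 to compound 4 (0.14 log units; within the scatter) is expected, because the earlier swap gave a 1.6-fold higher number from compound 1 to compound 2 (0.21 log units; within the scatter) and compound 3 starts from 1370 nM. Compound 4 is therefore estimated at 1900 nM, with 900 nM to 4000 nM as the expected range.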

Compound 4, half-maximal inhibitory concentration: 890 nM
For compound 4 the middle estimate is 2.1-fold (0.33 log units) above the measured one, and the stated range ends above it.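

In this assay, chloro in place of fluoro, on the aromatic carbon para to a large group on the core of compound 3, gives a 1.5-fold lower number from compound 3 to compound 4 (0.19 log units; within the scatter), a step too small to separate the two compounds. Set beside the earlier swap on the core of compound 1, this step does not differ from it: the same change on two cores in this assay, a 1.6-fold higher number (0.21 log units; within the scatter) from compound 1 to compound 2 and a 1.5-fold lower number (0.19 log units; within the scatter) from compound 3 to compound 4, 2.5-fold (0.39 log units) apart, within the scatter of two such steps. The swap therefore stays within the scatter on both cores, but this does not show that it carries over with a fixed size or direction, and the two steps cannot separate the effect of the core from that of the halogen's place on the ring, as the two pairs differ in both.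

The compounds shown leave open whether bromo, methoxy or trifluoromethyl on the urea aryl ring would move the number beyond the scatter on either core. Going by these compounds alone, they also leave open how the fluoro to chloro swap reads at the place para to a large group on the core of compound 1, the one pair that would test the core alone.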